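This account rests on a few compounds, and the source may have more. Where it says the series, first, only, none or still open, it means among the compounds named here.

Compound 1 `COc1cc(C(=O)c2ccc3c(ccn3S(=O)(=O)c3cccc(/C=C/C(=O)NO)c3)c2)cc(OC)c1OC` and compound 2 `Cc1ccc(C(=O)c2ccc3c(ccn3S(=O)(=O)c3cccc(/C=C/C(=O)NO)c3)c2)cc1` share a core and differ only in the ring that sits on the carbonyl carbon. In an assay on isolated protein for inhibition of polyamine deacetylase HDAC10 (Homo sapiens) (a higher number here means a weaker inhibitor, a lower number a stronger inhibitor), compound 1 gives only a limit, > 100000 nM. In this assay, among the compounds with values here, compound 2 gives 9100 nM, the only full number reported among the two. The step of an at least 10-fold lower number from compound 1 to compound 2 (1.04 log units; beyond the scatter) rests on that limit (the limit of > 100000 nM in this assay, at which 1 of the 2 values shown sits), so only its lower bound is known. Compound 3 `COc1ccc(C(=O)c2ccc3c(ccn3S(=O)(=O)c3cccc(/C=C/C(=O)NO)c3)c2)cc1` keeps everything of compound 2 except one group: methoxy in place of methyl on an aromatic carbon. Within the data shown here, the single measured step bearing on this ring swapped a 3,4,5-trimethoxyphenyl for a 4-methylphenyl and came out large; a single methoxy in place of methyl is a far smaller change, and a shift toward a somewhat higher number, roughly at the edge of the scatter, is expected. The estimate for compound 3 is 14000 nM, between 5000 nM and 45000 nM, a step of a 1.5-fold higher number from compound 2 to compound 3 (0.19 log units; within the scatter).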

Compound 3, half-maximal inhibitory concentration: 5890 nM
Beside the measured number, compound 3's estimate is 2.4-fold (0.38 log units) above it, and the stated range covers the measured number.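

In this assay, methyl and methoxy on this aromatic carbon cannot be told apart: the step reads a 1.5-fold lower number from compound 2 to compound 3 (0.19 log units; within the scatter). A lone methoxy on this ring is therefore compatible with the activity of compound 2, and the ring of compound 3 differs from that of compound 1 by two further methoxy groups, with a step of an at least 16-fold lower number from compound 1 to compound 3 (1.22 log units; beyond the scatter). Compound 1 gives only a limit, so this step is known only as a lower bound: the limit of > 100000 nM in this assay, at which 1 of the 3 values shown sits.

The compounds shown do not tell whether both further methoxy groups are needed for the loss or whether one alone would produce it. Nor do they show how a chlorine, a hydroxyl or an amine on this same aromatic carbon would compare with methyl and methoxy.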